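The compounds below may be only part of what the source reports. "The series", "measured", "known", "first", "only" and "open" are said of these compounds alone.

Measured compounds of the series:
compound 1, `O=C(Nc1cccc(-c2oc3cc(-c4ccc(F)cc4)ccc3c(=O)c2O)c1)c1ccccc1F`: in a functional assay on HCC1937 cells (Homo sapiens) for antiproliferative activity, read by CCK-8 assay, with a stated time of 72 h (a higher number here means a weaker inhibitor, a lower number a stronger inhibitor), compound 1 gives 10800 nM.
compound 2, `O=C(Nc1cccc(-c2oc3cc(-c4ccc(F)cc4)ccc3c(=O)c2O)c1)c1ccc(F)cc1`: in this assay compound 2 gives 14200 nM.
compound 3, `COc1cccc(C(=O)Nc2cccc(-c3oc4cc(-c5ccc(F)cc5)ccc4c(=O)c3O)c2)c1`: in this assay compound 3 gives 18900 nM.

All three share one core and differ only in the aryl on the carbonyl carbon of the amide. Compound 3 gives the highest of the three numbers, but none of the three separate from each other: a 1.8-fold higher number from compound 1 to compound 3 (0.24 log units; within the scatter), a 1.3-fold higher number from compound 2 to compound 3 (0.12 log units; within the scatter), and a 1.3-fold higher number from compound 1 to compound 2 (0.12 log units; within the scatter). Swapping a fluorine for a methoxy, or moving the fluorine around that ring, has so far moved nothing beyond the scatter.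

Compound 4, `COc1ccc(C(=O)Nc2cccc(-c3oc4cc(-c5ccc(F)cc5)ccc4c(=O)c3O)c2)c(F)c1`, is not yet measured. It differs from compound 3 by 2-fluoro-4-methoxyphenyl in place of 3-methoxyphenyl on a carbonyl carbon. For the measured compounds named here, the steps that bear on it are the three aryl swaps above, each within the scatter, and compound 4 combines a fluorine and a methoxy that have each been tried separately. No step beyond the scatter is expected in this assay, in either direction. For compound 4 the step expected is a 1.2-fold lower number from compound 3 to compound 4 (0.07 log units; within the scatter). Compound 4 is therefore estimated at 16000 nM, with a range from 7000 nM to 36000 nM.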

Compound 4, half-maximal inhibitory concentration: 24500 nM
Compound 4: the middle estimate sits 1.5-fold (0.19 log units) below what was measured; the measured number falls inside the stated range.
By their numbers in this assay, from the lowest: compounds 1, 2, 3 and 4 (each within the scatter of the next, the first and the last beyond it).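

Methoxy in place of hydrogen on an aromatic carbon of the 2-fluorophenyl group gives the first step beyond the scatter in this series in this assay, though a modest one (a 2.3-fold higher number from compound 1 to compound 4 (0.36 log units; beyond the scatter)). The same aryl group stays within the scatter against the other two it can be compared with (a 1.3-fold higher number from compound 3 to compound 4 (0.11 log units; within the scatter)) and (a 1.7-fold higher number from compound 2 to compound 4 (0.24 log units; within the scatter)), so this position is not entirely flat, but the shift is visible only against 2-fluorophenyl. Nothing available accounts for this step.

The aryl groups shown carry only fluorine and methoxy, so it remains open whether an amine or a carboxylic acid on this ring would shift the number further. As far as these compounds go, whether a longer alkoxy chain in place of methoxy would extend the step or reverse it also remains open.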